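Replacing the Sugar Group on Compound 1

The source may report more compounds than this note shows. Statements on the series, on what has been measured and on what is new or still open speak of the compounds shown alone.

Measured in a toxicity assay on L02 cells (Homo sapiens) for cytotoxicity, read by MTT assay, with a stated time of 72 h; on this read-out lower numbers stand for stronger inhibition and higher numbers for weaker inhibition:
compound 1 `O=C1c2c[n+]([O-])c3ccccc3c2C(=O)c2c1c1ccccc1n2Cc1cn([C@H]2O[C@H](CO)[C@@H](O)[C@H]2O)nn1` — 950 nM
compound 2 `O=C1c2c[n+]([O-])c3ccccc3c2C(=O)c2c1c1ccccc1n2CCCCn1ccnc1` — 150 nM
compound 3 `O=C1c2c[n+]([O-])c3ccccc3c2C(=O)c2c1c1ccccc1n2CCCCN1CCNCC1` — 1380 nM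

Compound 1 sits near compound 3, within the scatter, and beyond the scatter above compound 2. Within the data shown here, the one measured step, a 9.2-fold higher number from compound 2 to compound 3 (0.96 log units; beyond the scatter), concerns the chain on the indole-type nitrogen of the shared core, not the group that changes here.

Compound 4 `CC1(C)OC[C@@H](Cn2cc(Cn3c4c(c5ccccc53)C(=O)c3c[n+]([O-])c5ccccc5c3C4=O)nn2)O1` differs from compound 1 in one place: (2,2-dimethyl-1,3-dioxolan-4-yl)methyl in place of 3,4-dihydroxy-5-(hydroxymethyl)oxolan-2-yl on an aromatic nitrogen. Among the measured compounds shown here, no measured pair shows this kind of exchange, so the data give no direction for it. Compound 4 is therefore expected to stay close to compound 1, with a step of a 1.1-fold lower number from compound 1 to compound 4 (0.02 log units; within the scatter) that is not expected to pass beyond the scatter. The estimate for compound 4 in this assay is 900 nM, with a range from 300 nM to 2700 nM.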

Compound 4, half-maximal inhibitory concentration: 2900 nM
The estimate for compound 4 lay 3.2-fold (0.51 log units) below the measured number; measured number outside the range, above it.
By their numbers in this assay, from the lowest: compound 2; then compounds 1 and 3 (each within the scatter of the next); then compound 4.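

On an aromatic nitrogen of the triazole-type five-membered ring of compound 1, the group itself matters in this assay: (2,2-dimethyl-1,3-dioxolan-4-yl)methyl in place of 3,4-dihydroxy-5-(hydroxymethyl)oxolan-2-yl gives a step beyond the scatter (a 3.1-fold higher number from compound 1 to compound 4 (0.48 log units; beyond the scatter)). The group that enters has 0 hydrogen-bond donors against 3 and 1 defined stereocentre against 4, and this single pair cannot separate these differences. Nothing measured here accounts for the step.

On these data alone, how an amine, a carboxylic acid or a longer chain would read at this place remains open.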